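Swapping a Thiazolyl Sulfide for a Pyridyl Sulfide

The source may hold more compounds than are shown below. What is called first, only, known or untested is meant among the compounds shown, and "the series" means these compounds.

Of the compounds shown here, three built on a shared core have been measured in a functional assay on MGC-803 cells (Homo sapiens) for inhibition, read by MTT assay, with a stated time of 72 h; a higher number here means a weaker inhibitor, a lower number a stronger inhibitor. Compound 1 `CN1CCN(c2cc(C(F)(F)F)nc(SCc3ccc(C(F)(F)F)cc3)n2)CC1` gives 15800 nM. Compound 2 `CCN1CCN(c2cc(C(F)(F)F)nc(SCc3ccc(C(F)(F)F)cc3)n2)CC1`, carrying methyl in place of hydrogen on a saturated chain carbon bound to an amine nitrogen in a ring, gives 25600 nM; the step between them reads a 1.6-fold higher number from compound 1 to compound 2 (0.21 log units; within the scatter). Compound 3 `Cc1csc(Sc2cc(C(F)(F)F)nc(SCc3ccc(C(F)(F)F)cc3)n2)n1` gives 21300 nM. Compound 3 stands second highest of the three numbers, with compound 2 nearest and compound 1 furthest; both a 1.3-fold higher number from compound 1 to compound 3 (0.13 log units; within the scatter) and a 1.2-fold lower number from compound 2 to compound 3 (0.08 log units; within the scatter) lie within the scatter, so none of the three can be called stronger or weaker than another.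

Compound 4 `FC(F)(F)c1ccc(CSc2nc(Sc3ccccn3)cc(C(F)(F)F)n2)cc1` differs from compound 3 at a single place: pyridin-2-yl in place of 4-methyl-1,3-thiazol-2-yl on a sulfur. For the measured compounds named here, no measured step touches this group itself, so nothing bears on it directly. What the data do show is that replacing the whole group on that aromatic carbon, as in a 1.2-fold lower number from compound 2 to compound 3 (0.08 log units; within the scatter), left the number within the scatter. The step expected in this assay is therefore a 1.0-fold higher number from compound 3 to compound 4 (0.01 log units; within the scatter), none beyond the scatter. Compound 4 is expected to give 22000 nM, with a range from 9000 nM to 55000 nM.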

Compound 4, half-maximal inhibitory concentration: > 50000 nM
Compound 4: only a limit was reported; the forecaster's own chance of this, stated with the estimate: 10%; at least 2.2-fold (0.35 log units) between middle value and limit.
By their numbers in this assay, from the lowest: compounds 1, 3 and 2 (each within the scatter of the next). At a limit, above all of these: compound 4.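

In this assay, compound 4 gave only a limit rather than a number: the limit of > 50000 nM in this assay, at which 1 of the 4 values shown sits. Every earlier step among the compounds at this aromatic carbon stayed within the scatter, whereas this change on the sulfur gives an at least 2.3-fold higher number from compound 3 to compound 4 (0.37 log units; beyond the scatter) even though the entering and leaving rings carry the same count of heavy atoms and neither bears a net charge, and the comparison with the methylpiperazine compound gives an at least 3.1-fold higher number from compound 1 to compound 4 (0.50 log units; beyond the scatter) as a second step that clears the scatter. The comparison with the ethylpiperazine compound is less decisive, since an at least 1.9-fold higher number from compound 2 to compound 4 (0.29 log units; that floor lies within the scatter) only sets a floor and does not separate the two compounds.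

The limit leaves open how large the step on the sulfur really is, and a single swap cannot tell whether it follows the ring size, the sulfur of the thiazole or the methyl group on it. Going by these compounds, how an unsubstituted thiazol-2-yl or a phenyl on the sulfur, or a morpholine on the aromatic carbon, would read against compound 3 and compound 4 also remains open.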